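Trifluoromethyl gives way to chloro in compound 4

This account rests on a few compounds, and the source may have more. Where it says the series, first, only, none or still open, it means among the compounds named here.

In a functional assay on the whole organism (strain Kunming) with Mus musculus as the target, with a stated time of 0.5 h (on this read-out lower numbers stand for an effect already at smaller amounts and higher numbers for an effect only at larger amounts of compound), compound 1 `COc1ccccc1/C=C/C(=O)OC/C=C/c1cc(OC)c(OC)cc1OC` gives 39 mg/kg as its dose, and compound 2 `COc1cc(OC)c(OC)cc1/C=C/COC(=O)/C=C/c1c(OC)ccc(OC)c1OC` gives 53.5 mg/kg on the same read-out. In this assay compound 3 `COc1cc(OC)c(OC)cc1/C=C/COC(=O)/C=C/c1ccccc1C(F)(F)F` comes in at 85.7 mg/kg and so sits within the usual scatter of compound 2 but clearly above compound 1.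

Compound 4 `COc1cc(OC)c(OC)cc1/C=C/COC(=O)/C=C/c1ccccc1Cl` differs from compound 3 by a single change (chloro in place of trifluoromethyl on an aromatic carbon) on an aromatic carbon, ortho to a large group: chloro stands in place of trifluoromethyl. For the measured compounds named here, no measurement yet compares these two groups directly. Going by the values given here, the one measured step that touches this spot is a 2.2-fold higher number from compound 1 to compound 3 (0.34 log units; beyond the scatter) when trifluoromethyl takes the place of methoxy on an aromatic carbon. That step is modest and only just clears the scatter, so replacing trifluoromethyl with another group is expected to move the number little, and any drift should lean towards the lower values seen so far. The expected change is a 1.4-fold lower number from compound 3 to compound 4 (0.15 log units; within the scatter) and so no real step beyond the scatter. The estimate for compound 4 in this assay is 60 mg/kg with an expected range from 32 mg/kg up to 110 mg/kg on this reasoning.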

Compound 4, dose for half-maximal effect: 58.7 mg/kg
The estimate for compound 4 lay 1.0-fold (0.01 log units) above the measured number; measured number inside the range.
By their numbers in this assay, from the lowest: compounds 1, 2, 4 and 3 (each within the scatter of the next, the first and the last beyond it).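

In this assay, for the compounds shown here, chloro in place of trifluoromethyl gives a 1.5-fold lower number from compound 3 to compound 4 (0.16 log units; within the scatter) and so, on an aromatic carbon ortho to a large group, the first direct comparison of these two groups shows no real separation between them. Chloro in place of methoxy gives a 1.5-fold higher number from compound 1 to compound 4 (0.18 log units; within the scatter) at the same spot, whereas trifluoromethyl in place of methoxy gave a 2.2-fold higher number from compound 1 to compound 3 (0.34 log units; beyond the scatter) and was the one change here to clear the scatter, which leaves compound 4 indistinguishable from both compound 1 and compound 3 even though those two stand apart. No measurement at hand bears on what lies behind these numbers.

As far as these compounds go, only methoxy, trifluoromethyl and chloro can be compared at this spot, so it remains open whether a quite different group, such as an amine, a carboxylic acid or a hydroxyl, would shift the dose well beyond the scatter in either direction. From the compounds shown here alone, it is also open whether the close match between chloro and trifluoromethyl would hold with other groups elsewhere on the shared core.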